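The compounds below may be only part of what the source reports. "The series", "measured", "known", "first", "only" and "open" are said of these compounds alone.

Measured compounds:
Compound 1, `C#CCSc1nc(Nc2ccc(C)cc2)c2ccncc2n1`, in a functional assay on MGC-803 cells (Homo sapiens) for inhibition, read by MTT assay, with a stated time of 72 h; on this read-out higher numbers stand for weaker inhibition and lower numbers for stronger inhibition: 8090 nM.
Compound 2, `C#CCSc1nc(Nc2ccc(Br)cc2)c2ccncc2n1`, in this assay: 26000 nM.

Compound 2 holds the highest of the two numbers; the step of a 3.2-fold higher number from compound 1 to compound 2 (0.51 log units; beyond the scatter) separates it from compound 1. The move to compound 3, `C#CCSc1nc(Nc2ccccc2O)c2ccncc2n1`, is 2-hydroxyphenyl in place of 4-bromophenyl on a nitrogen on an aromatic ring. Among the measured compounds shown here, no measured step covers this exchange; the only step in hand, from compound 1 to compound 2, shows that a change on the phenyl ring shifts the number modestly. The step from compound 2 to compound 3 is therefore expected to be small, a 1.9-fold lower number from compound 2 to compound 3 (0.27 log units; within the scatter), in no firm direction. Compound 3 is estimated at 14000 nM, within 3500 nM to 56000 nM.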

Compound 3, half-maximal inhibitory concentration: 21000 nM
Compound 3: middle estimate off by 1.5-fold (0.18 log units), on the low side; low and high end bracket the measured number.
By their numbers in this assay, from the lowest: compound 1; then compounds 3 and 2 (each within the scatter of the next).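

In this assay, 2-hydroxyphenyl in place of 4-bromophenyl on the nitrogen gives a 1.2-fold lower number from compound 2 to compound 3 (0.09 log units; within the scatter) and so stays within the scatter, although the entering group brings a hydrogen-bond donor and acceptor. Against the 4-methylphenyl group, the same position gives a 2.6-fold higher number from compound 1 to compound 3 (0.41 log units; beyond the scatter) and so lies beyond the scatter, leaving compound 1 apart from both others. No evidence at hand accounts for these numbers.

On these data alone, whether a 4-hydroxyphenyl, a 2-methoxyphenyl or a 4-aminophenyl group on this nitrogen would move the number stays open. So does the effect of a carboxylic acid on the phenyl ring.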